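This account rests on a few compounds, and the source may have more. Where it says the series, first, only, none or still open, it means among the compounds named here.

Measured in a functional assay on HepG2 cells (Homo sapiens) for antiproliferative activity, read by MTT assay; on this read-out lower numbers stand for stronger inhibition and higher numbers for weaker inhibition:

compound 1 `Nc1c(C(=O)N/N=C/c2ccccc2)oc2nc(-c3ccccc3)cc(C(F)(F)F)c12`: 13100 nM
compound 2 `Nc1c(C(=O)N/N=C/c2ccccc2)oc2nc(-c3cccs3)cc(C(F)(F)F)c12`: 9900 nM

Compound 1 gives the highest of these two numbers, and compound 2 sits nearest to it: the change from compound 1 to compound 2 is a thiophen-2-yl in place of a phenyl on an aromatic carbon of the shared core, and the step of a 1.3-fold lower number from compound 1 to compound 2 (0.12 log units; within the scatter) lies within the scatter, so the two compounds cannot be told apart on this read-out.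

Compound 3 `Nc1c(C(=O)N/N=C/c2ccc(Cl)cc2)oc2nc(-c3ccccc3)cc(C(F)(F)F)c12` differs from compound 1 by chloro in place of hydrogen on an aromatic carbon. Going by the values given here, this is a different place from the one that separates compound 1 and compound 2, so no measured step bears directly on it; the only step known, a 1.3-fold lower number from compound 1 to compound 2 (0.12 log units; within the scatter), shows the core tolerating a small change without a shift beyond the scatter. A step of a 1.3-fold lower number from compound 1 to compound 3 (0.12 log units; within the scatter) is therefore expected, meaning no change beyond the scatter, and compound 3 is estimated at 10000 nM, within a range of 3500 nM to 30000 nM.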

Compound 3, half-maximal inhibitory concentration: 12100 nM
Beside the measured number, compound 3's estimate is 1.2-fold (0.08 log units) below it; the measured number falls inside the stated range.
By their numbers in this assay, from the lowest: compounds 2, 3 and 1 (each within the scatter of the next).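

With the step of a 1.1-fold lower number from compound 1 to compound 3 (0.03 log units; within the scatter) in this assay, the read-out now has a second place on the shared core to speak to: the phenyl of the benzylidene end, which turns into 4-chlorophenyl. A single chlorine on this ring, para to a large group, leaves compound 3 indistinguishable from compound 1, just as the change at the other place left compound 2 indistinguishable from it, so neither place has yet shown a change beyond the scatter. Nothing available explains this result.

As far as these compounds go, whether this ring would respond to a different kind of group, such as an amine, a carboxylic acid or a longer chain, remains open. Also open, from the compounds shown here alone, is whether chloro and thiophen-2-yl together on one molecule would give a number that differs beyond the scatter.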